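The compounds below may be only part of what the source reports. "The series", "measured", "known", "first", "only" and "open" are said of these compounds alone.

Working notes on the series. In a functional assay on MCF7 cells (Homo sapiens) for inhibition, read by MTT assay, with a stated time of 24 h (a higher number here means a weaker inhibitor of growth, a lower number a stronger inhibitor of growth), compound 1 `Cn1cc(-c2nc3ccccc3n2C(=O)c2ccccc2)c2ccccc21` gives 43700 nM and compound 2 `Cn1cc(-c2nc3ccccc3n2C(=O)c2ccccc2Br)c2ccccc21` gives 70100 nM while compound 3 `COc1ccc2c(c1)c(-c1nc3ccccc3n1C(=O)c1ccccc1)cn2C` gives 38400 nM and these three values all lie within the scatter of one another. Compound 3 therefore holds no separate rank in the set.

The next structure is compound 4 `COc1cccc(C(=O)n2c(-c3cn(C)c4ccc(OC)cc34)nc3ccccc32)c1` which differs from compound 3 on the benzoyl group, read as benzoyl to (3-methoxyphenyl)carbonyl. The counted difference is methoxy in place of hydrogen on an aromatic carbon and it amounts to methoxy in place of hydrogen on an aromatic carbon, meta to a large group.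

Going by the values given here, two measured steps bear on this. The step of a 1.6-fold higher number from compound 1 to compound 2 (0.21 log units; within the scatter) puts bromo in place of hydrogen on the benzoyl group, and the step of a 1.1-fold lower number from compound 1 to compound 3 (0.06 log units; within the scatter) puts methoxy in place of hydrogen elsewhere in the molecule. Both stay within the scatter. Among the compounds with values here, no measured compound carries a methoxy on the benzoyl group, so the evidence is indirect, and no step beyond the scatter is expected in either direction. The expected step is a 1.0-fold lower number from compound 3 to compound 4 (0.00 log units; within the scatter) and it stays within the scatter. For compound 4 the estimated value is 38000 nM with an expected range from 18000 nM to 78000 nM as the working figure.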

Compound 4, concentration for 50% growth inhibition: 14600 nM
Compound 4: middle estimate off by 2.6-fold (0.42 log units), on the high side; the measured number lies below the stated range.
By their numbers in this assay, from the lowest: compound 4; then compounds 3, 1 and 2 (each within the scatter of the next).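

In this assay, going by these compounds alone, methoxy in place of hydrogen on the benzoyl group, meta to a large group, gives a 2.6-fold lower number from compound 3 to compound 4 (0.42 log units; beyond the scatter) and so provides the first step to pass the scatter, though only modestly. The same replacement elsewhere in the molecule, a 1.1-fold lower number from compound 1 to compound 3 (0.06 log units; within the scatter) and thus within the scatter, did not show this, nor did bromo in place of hydrogen on the benzoyl group, a 1.6-fold higher number from compound 1 to compound 2 (0.21 log units; within the scatter) and also within the scatter, so among these three steps only methoxy at this position moves the number beyond the scatter. Nothing at hand accounts for this difference between the steps.

From the compounds shown here alone, it remains open whether the 3-methoxyphenyl change gives a step of similar size on the core of compound 1, which lacks the other methoxy carried by compound 3 and compound 4. Going by these compounds, it is also open whether this position is specific to methoxy or would respond in the same way to a different group, such as a hydroxyl, an amine, a carboxylic acid or a longer chain.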